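This account rests on a few compounds, and the source may have more. Where it says the series, first, only, none or still open, it means among the compounds named here.

Measured in a functional assay on SW-620 cells (Homo sapiens) for cytotoxicity, read by MTT assay, with a stated time of 72 h; a lower number here means a stronger inhibitor, a higher number a weaker inhibitor:
- Compound 1 `COc1cccc(/C=C2\CCC/C(=C\c3cccc(Cl)c3)C2=O)c1OC`: 9100 nM
- Compound 2 `COc1ccccc1/C=C1\CCC/C(=C\c2cccc(OC)c2OC)C1=O`: > 20000 nM
- Compound 3 `COc1ccc(/C=C2\CCC/C(=C\c3ccc(Cl)cc3)C2=O)cc1OC`: 5900 nM

The entry for compound 2, > 20000 nM, is a limit of the assay and not a number. Compound 3 at 5900 nM and compound 1 at 9100 nM lie within the scatter of each other.

Compound 4 `COc1ccc(/C=C2\CCC/C(=C\c3ccc(OC)c(OC)c3)C2=O)cc1` departs from compound 3 in one place: methoxy in place of chloro on an aromatic carbon. This is methoxy in place of chloro on an aromatic carbon, 4-chlorophenyl to 4-methoxyphenyl.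

Among the measured compounds shown here, one measured step bears on this change: an at least 2.1-fold higher number from compound 1 to compound 2 (0.34 log units; beyond the scatter). There, 2-methoxyphenyl replaces 3-chlorophenyl, so the parallel is only partial, and the step ends at a limit. Even so, it points the same way, and a modest rise in the number is expected in this assay. The estimated change is a 1.9-fold higher number from compound 3 to compound 4 (0.27 log units; within the scatter). For compound 4 the expected value is 11000 nM, with an estimated range of 5000 nM to 20000 nM.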

Compound 4, half-maximal inhibitory concentration: 6600 nM
Compound 4: middle estimate off by 1.7-fold (0.22 log units), on the high side; measured number inside the range.
By their numbers in this assay, from the lowest: compounds 3, 4 and 1 (each within the scatter of the next). At a limit, above all of these: compound 2.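

In this assay, methoxy in place of chloro on an aromatic carbon, para to a large group, gives a 1.1-fold higher number from compound 3 to compound 4 (0.05 log units; within the scatter), so at this position the exchange of 4-chlorophenyl for 4-methoxyphenyl leaves the number within the scatter. The earlier step, an at least 2.1-fold higher number from compound 1 to compound 2 (0.34 log units; beyond the scatter), involved a different pair of groups and gave no number at its far end, whereas this step is read directly between two numbers on a single change. For that earlier step, compound 2 stands at a limit of the assay and not at a number: the limit of > 20000 nM in this assay, at which 1 of the 4 values shown sits.

The compounds shown leave open whether an amine or a carboxylic acid at this position would keep the number in the same range in this assay. They also leave open whether the same exchange on the other aromatic ring of the shared core would read the same way.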